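This account rests on a few compounds, and the source may have more. Where it says the series, first, only, none or still open, it means among the compounds named here.

Measured so far:
compound 1 `Oc1ccc(O)c(COCc2cc(O)cc(Cl)c2O)c1` — 5800 nM in a functional assay on MOLT-4 cells (Homo sapiens) for cytotoxicity, read by MTT assay; a higher number here means a weaker inhibitor, a lower number a stronger inhibitor
compound 2 `Oc1ccc(O)c(COCc2cc(O)ccc2O)c1` — 5600 nM
compound 3 `OCc1cc(OCc2cc(O)ccc2O)cc(Cl)c1O` — 5500 nM

Compound 3 gives the lowest of the three numbers, but its nearest neighbour is compound 2 and its furthest is compound 1, and both gaps lie within the scatter, so the three compounds cannot be told apart on these data.

Compound 4 `OCc1cc(OCc2cc(O)ccc2O)ccc1O` differs from compound 3 in one place: hydrogen in place of chloro on an aromatic carbon. Going by the values given here, one measured step bears on this change, and it is of the same kind: a 1.0-fold lower number from compound 1 to compound 2 (0.02 log units; within the scatter), a step within the scatter. Compound 4 is therefore expected to show no step beyond the scatter, no change at the digits printed from compound 3 to compound 4 (within the scatter). In this assay compound 4 is estimated at 5500 nM, with a range from 2700 nM to 11000 nM.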

Compound 4, half-maximal inhibitory concentration: 6400 nM
Compound 4: middle estimate off by 1.2-fold (0.07 log units), on the low side, within the range that was stated.
By their numbers in this assay, from the lowest: compounds 3, 2, 1 and 4 (each within the scatter of the next).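

Compound 3 carries its chloro on an aromatic carbon ortho to a hydroxy group, and the exchange for hydrogen there now has a reading on a second core: in this assay, the step is a 1.2-fold higher number from compound 3 to compound 4 (0.07 log units; within the scatter). On neither core does this exchange give a step beyond the scatter, and the two steps agree with each other: the same change on two cores in this assay, a 1.0-fold lower number (0.02 log units; within the scatter) from compound 1 to compound 2 and a 1.2-fold higher number (0.07 log units; within the scatter) from compound 3 to compound 4, 1.2-fold (0.08 log units) apart, within the scatter of two such steps

The compounds shown carry only chloro or hydrogen at this position, so it stays open whether an amine or a carboxylic acid there would give a step beyond the scatter.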